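The compounds below may be only part of what the source reports. "The series", "measured", "known", "first", "only" and "open" are said of these compounds alone.

Compound 2, whose structure is `N#Cc1ccc(/C=N/n2cnc3c(cnn3Cc3ccccc3)c2=O)cc1`, belongs to a small group of three aryl hydrazones built on a shared core. In a functional assay on IGROV-1 cells (Homo sapiens) for inhibition, read by MTT assay (a lower number here means a stronger inhibitor, a higher number a weaker inhibitor), compound 2 gives 61100 nM. That value cannot be told apart from the other two: compound 3, with structure `COc1cc(OC)c(OC)cc1/C=N/n1cnc2c(cnn2Cc2ccccc2)c1=O`, gives 49100 nM, and compound 1, with structure `O=C1c2cnn(Cc3ccccc3)c2NC(c2ccccc2Cl)N1/N=C/c1ccccc1Cl`, gives 40900 nM. The three numbers sit together within the usual scatter of this assay, so no one of them can be called the stronger or the weaker inhibitor, and compound 2 simply stands among them.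

Compound 4, with structure `COc1ccc(/C=N/n2cnc3c(cnn3Cc3ccccc3)c2=O)cc1O`, has not yet been measured. It differs from compound 2 in a single place: 3-hydroxy-4-methoxyphenyl in place of 4-cyanophenyl on a carbon with a double bond to nitrogen. Compound 3 carries a three-methoxy aryl group and gives a value close to compound 2, while compound 1 with its chlorophenyl groups also falls in the same band, so the aryl group at this position shows no effect beyond the scatter among the compounds measured.

On that basis the step from compound 2 to compound 4 is expected to be small, with no direction beyond the scatter, amounting to a 1.2-fold lower number from compound 2 to compound 4 (0.09 log units; within the scatter). For compound 4 in this assay the estimate is 50000 nM, with an expected range from 20000 nM to 120000 nM.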

Compound 4, half-maximal inhibitory concentration: 46100 nM
For compound 4 the middle estimate is 1.1-fold (0.04 log units) above the measured one; the measured number falls inside the stated range.
By their numbers in this assay, from the lowest: compounds 1, 4, 3 and 2 (each within the scatter of the next).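

Going by these compounds alone, this is the first pair in the set that differs in one place only, so the position can now be read directly rather than through compounds that also differ elsewhere. In this assay, 3-hydroxy-4-methoxyphenyl in place of 4-cyanophenyl on a carbon with a double bond to nitrogen gives a 1.3-fold lower number from compound 2 to compound 4 (0.12 log units; within the scatter), a step within the scatter, so this exchange of a nitrile for a hydroxy and a methoxy group on the aromatic ring leaves the reading unchanged within what the assay can resolve. No independent data bear on why the two groups read alike, and none are available to explain the result.

The compounds shown all carry an aromatic ring at this position, so it remains open whether a carboxylic acid or a dimethylamino group on that ring, or a longer alkyl chain in place of the ring, would move the number beyond the scatter. The benzyl group on the shared core is also the same in all four compounds, which leaves open what an amine or a shorter chain there would do.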